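Adding a nitro group to compound 2: outlook for compound 4

The source may report more compounds than this note shows. Statements on the series, on what has been measured and on what is new or still open speak of the compounds shown alone.

Compound 1, `Cc1cc(NC(=O)c2ccc(Cl)c([N+](=O)[O-])c2)ccc1NS(C)(=O)=O`: 108000 nM in an ADME assay on RAW264.7 cells (Mus musculus) for cytotoxicity, read by MTT assay, with a stated time of 48 h; a higher number here means a weaker inhibitor, a lower number a stronger inhibitor.
Compound 2, `COc1cc(NC(=O)c2ccc(Cl)cc2)ccc1NS(C)(=O)=O`: 70000 nM.
Compound 3, `COc1cc(NC(=O)c2ccc(C#N)cc2)ccc1NS(C)(=O)=O`: a limit of > 250000 nM.

In this assay compound 2 and compound 1 give numbers within the scatter of each other. For compound 3 only a limit is recorded (the limit of > 250000 nM in this assay, at which 1 of the 3 values shown sits). Compound 4, `COc1cc(NC(=O)c2ccc(Cl)c([N+](=O)[O-])c2)ccc1NS(C)(=O)=O`, differs from compound 2 by nitro in place of hydrogen on an aromatic carbon. For the measured compounds named here, the only measured one-place step, an at least 3.5-fold higher number from compound 2 to compound 3 (0.55 log units; beyond the scatter), concerns a different group and does not bear on a nitro addition. Compound 1 carries both chloro and nitro but differs from compound 2 in two places, so their two values show nothing more than agreement within the scatter. Going by the values given here, no measured step sets the size; in this assay a step no larger than the scatter, in either direction, is expected, a 1.3-fold higher number from compound 2 to compound 4 (0.11 log units; within the scatter). Compound 4 is estimated at 90000 nM, with a range from 45000 nM to 180000 nM.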

Compound 4, half-maximal inhibitory concentration: > 250000 nM
Compound 4: no number, only a limit; the forecaster's own chance of this, stated with the estimate: 10%; middle value at least 2.7-fold (0.44 log units) away from the limit.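

Nitro in place of hydrogen on an aromatic carbon, ortho to a chloro group, gives an at least 3.5-fold higher number from compound 2 to compound 4 (0.55 log units; beyond the scatter) in this assay and is the first measured step at this position. With chloro and nitro both kept, methoxy in place of methyl gives an at least 2.3-fold higher number from compound 1 to compound 4 (0.36 log units; beyond the scatter) as a second measured change, so the other place on the core also matters in the presence of nitro. Compound 4 gives a limit and not a number, so both steps are only bounds: the limit of > 250000 nM in this assay, at which 2 of the 4 values shown sit.

On these data alone, the true size of either step stays open. Also open, as far as these compounds go, is whether an amine or a carboxylic acid at this position would give a number in this assay rather than another limit.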